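This account rests on a few compounds, and the source may have more. Where it says the series, first, only, none or still open, it means among the compounds named here.

Of the compounds shown here, two have so far been measured in a functional assay on MIA PaCa-2 cells (Homo sapiens) for inhibition, read by MTT assay, with a stated time of 48 h, tested at 10 uM; on this read-out higher numbers stand for more inhibition of growth at the one concentration tested and lower numbers for less inhibition of growth. Compound 1 `O=C(/C=C/c1ccc(OCc2cn(Cc3cccc(Br)c3)nn2)cc1)c1ccc(Br)cc1` gives 43% in this assay. Within the data shown here, compound 2 `COc1ccc(C(=O)/C=C/c2ccc(OCc3cn(Cc4ccccc4)nn3)cc2)cc1` gives 68% in this assay, the higher of the two numbers, and its only neighbour, compound 1, lies lower by a margin beyond the usual scatter. Among the measured compounds shown here, the two measured compounds differ from each other in two places at once, so their values show only that the pair sits apart, not which change is responsible.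

Compound 3 `COc1ccc(C(=O)/C=C/c2ccc(OCc3cn(Cc4cccc(Br)c4)nn3)cc2)cc1` differs from compound 2 in one place: bromo in place of hydrogen on an aromatic carbon, meta to a large group, so that the benzyl of compound 2 becomes a 3-bromobenzyl. For the measured compounds named here, no measured pair isolates this change. Compound 1 carries the same 3-bromobenzyl and gives the lower of the two measured numbers. Its ketone-bearing ring, however, also differs from that of compound 2, so the two measured values alone do not separate the two changes. The step from compound 2 to compound 3 is therefore expected to be a small decrease, a number 10 percentage points lower from compound 2 to compound 3 (within the scatter), close to the scatter. Compound 3 is estimated at 58%, within a range from 40% to 76%.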

Compound 3, percent growth inhibition at one concentration: 50%
The estimate for compound 3 lay 8 percentage points above the measured number; the measured number falls inside the stated range.
By their numbers in this assay, from the lowest: compounds 1 and 3 (each within the scatter of the next); then compound 2.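

Bromo in place of hydrogen on an aromatic carbon, meta to a large group, now stands alone in one pair, and in this assay the change from benzyl to 3-bromobenzyl gives a number 18 percentage points lower from compound 2 to compound 3 (beyond the scatter), the first effect of this change that can be read by itself. With the 3-bromobenzyl held constant, methoxy in place of bromo on an aromatic carbon gives a number 7 percentage points higher from compound 1 to compound 3 (within the scatter), so of the two changes that separate compound 1 from compound 2, only the change to 3-bromobenzyl has a step beyond the scatter in the pairs shown. The data offer no measurement that would explain the size of this step.

From the compounds shown here alone, whether a fluoro group, a methoxy group or an amine at this same place would give a step of similar size remains open, and so does whether the step belongs to bromo in particular or to any group there. Going by these compounds, it also remains open whether the step from benzyl to 3-bromobenzyl would hold in a compound that carries bromo instead of methoxy on its other aromatic ring.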